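Chlorophenyl series: removing the chloro, cytotoxicity in HEK293

The source may hold more compounds than are shown below. What is called first, only, known or untested is meant among the compounds shown, and "the series" means these compounds.

Measured compounds:
- compound 1 `Cc1cc(O)c(C(=O)/C=C/c2ccccc2)c(-c2ccc(Cl)cc2)c1C(=O)/C=C/c1ccccc1` — 5000 nM
- compound 2 `COc1ccc(/C=C/C(=O)c2c(C)cc(O)c(C(=O)/C=C/c3ccc(OC)cc3)c2-c2ccc(OCc3ccccc3)cc2)cc1` — 28000 nM
- compound 3 `Cc1cc(O)c(C(=O)/C=C/c2ccc(Cl)cc2)c(-c2ccc(Cl)cc2)c1C(=O)/C=C/c1ccc(Cl)cc1` — "not active" (no number reported)

Among the measured compounds shown here, the shared core carries two enone arms and a pendant aryl group; the three measured members differ in the substituents on these aryl rings. In an ADME assay on HEK293 cells (Homo sapiens) for cytotoxicity, read by MTT assay, with a stated time of 24 h (a higher number here means a weaker inhibitor, a lower number a stronger inhibitor), compound 1 gives 5000 nM, the lowest of the two numbers available. Compound 2 gives 28000 nM, a higher number by a margin beyond the scatter. Compound 3 is reported only as "not active" (no number reported), with no number given, so it cannot be placed on the scale.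

Compound 4 `Cc1cc(O)c(C(=O)/C=C/c2ccccc2)c(-c2ccccc2)c1C(=O)/C=C/c1ccccc1` has not been measured. It differs from compound 1 in one place: hydrogen in place of chloro on an aromatic carbon. For the measured compounds named here, no pair of measured compounds shows this exact change on its own, so the size of the step is an open question. Going by the values given here, the numbers seen so far run from compound 1 as the lowest toward compound 2 and then compound 3 without a number, and the chloro is the single feature that sets compound 1 apart from compound 4.

For compound 4 the expected step of a 1.6-fold higher number from compound 1 to compound 4 (0.20 log units; within the scatter) is modest, toward a higher number, not clearly beyond the scatter. The estimate for compound 4 in this assay is 8000 nM, within a range from 3000 nM to 30000 nM, with a real chance that only an inactive call is returned.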

Compound 4, half-maximal inhibitory concentration: "not active" (no number reported)
Compound 4: no number reported; the estimate stays without a comparison.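

In this assay compound 4 is reported as "not active" (no number reported) with no number, while compound 1 gives 5000 nM, and no step can be read between them. The compounds shown leave open how large the change from 4-chlorophenyl to phenyl is on its own in this assay. Nothing available bears on this result.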